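A few compounds are considered here, and "the series" means these few. Any claim that something is new, unique, unknown or untested is made for them only; others in the source may bear on it.

Measured so far in an assay on HL-60 cells for agonist activity at vitamin D3 receptor (Homo sapiens), read by microscopy, with a stated time of 96 h; on this read-out lower numbers stand for an effect already at smaller amounts and higher numbers for an effect only at larger amounts of compound:
compound 1 `CCn1c(C(=O)NCCCN(C)C)ccc1C(CC)(CC)c1ccc(OCC(O)C(C)(C)C)c(C)c1` — 37 nM
compound 2 `CCn1c(C(=O)N(C)c2ccccc2)ccc1C(CC)(CC)c1ccc(OCC(O)C(C)(C)C)c(C)c1` — 6400 nM

Compound 2 stands at the highest of the two numbers shown in this assay; its nearest neighbour is compound 1, reached by a 170-fold higher number from compound 1 to compound 2 (2.24 log units; beyond the scatter). Compound 3 `CCn1c(C(=O)N(C)CC(=O)O)ccc1C(CC)(CC)c1ccc(OCC(O)C(C)(C)C)c(C)c1` differs from compound 2 by carboxymethyl in place of phenyl on an amide-type nitrogen, the whole of it a carboxymethyl in place of phenyl on an amide-type nitrogen. Among the measured compounds shown here, only one measured step touches this position: the large one from compound 1 to compound 2, which shows that the group carried by the amide nitrogen can move the number a long way in this assay. Whether the carboxymethyl will behave more like the chain of compound 1 or like the phenyl of compound 2 the two measured compounds cannot tell. A step of a 3.2-fold lower number from compound 2 to compound 3 (0.51 log units; beyond the scatter) toward a lower number is therefore expected for compound 3, with wide uncertainty. Compound 3 is estimated at 2000 nM, between 400 nM and 10000 nM.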

Compound 3, half-maximal effective concentration: 740 nM
Beside the measured number, compound 3's estimate is 2.7-fold (0.43 log units) above it, and the stated range covers the measured number.
By their numbers in this assay, from the lowest: compound 1; then compound 3; then compound 2.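

In this assay, carboxymethyl in place of phenyl on the amide-type nitrogen gives an 8.6-fold lower number from compound 2 to compound 3 (0.94 log units; beyond the scatter), which shows that this position does not need an aromatic ring to reach a lower number than that of compound 2. The chain of compound 1 still gives the lowest number of the series, with a 20-fold higher number from compound 1 to compound 3 (1.30 log units; beyond the scatter), so the gain from losing the phenyl recovers only part of the distance to compound 1. Nothing available here accounts for either step.

Compound 1 carries the amide hydrogen where compound 3 carries a methyl, so the compounds shown leave open how much of that last step belongs to the methyl and how much to the chain. Also open, on these data alone, is how a 3-(dimethylamino)propyl chain would read on the methyl-bearing nitrogen, or a methyl ester in place of the carboxylic acid.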